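This account rests on a few compounds, and the source may have more. Where it says the series, first, only, none or still open, it means among the compounds named here.

Measured so far:
- compound 1 `CC(C)(C)c1cc2c(N/N=C/c3ccc(O)cc3)ncnc2s1`: > 10 ug/mL
- compound 2 `CC(C)(C)c1cc2c(N/N=C/c3ccc4c(c3)CNC4)ncnc2s1`: 0.071 ug/mL

Notes on the series. In a functional assay on PC-6 cells (Homo sapiens) for cytotoxicity, read by MTT assay, with a stated time of 3 days (on this read-out lower numbers stand for stronger inhibition and higher numbers for weaker inhibition), compound 1 gives only a limit, > 10 ug/mL, and no number. Compound 1 thus sits at the limit of > 10 ug/mL in this assay, at which 1 of the 2 values shown sits. Compound 2 gives 0.071 ug/mL in this assay. Compound 3 `CC(C)(C)c1cc2c(N/N=C/c3ccccc3)ncnc2s1` differs from compound 1 by hydrogen in place of hydroxy on an aromatic carbon. Within the data shown here, with no measured step of this kind to lean on, no shift beyond the scatter is expected for a number no higher from compound 1 to compound 3 (the limit leaves the size open), and compound 3 is estimated near 10 ug/mL, between 3 ug/mL and 30 ug/mL, most likely reported again only as a limit.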

Compound 3, half-maximal inhibitory concentration: 6.54 ug/mL
The estimate for compound 3 lay 1.5-fold (0.18 log units) above the measured number; the measured number falls inside the stated range.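

In this assay, hydrogen in place of hydroxy on the aromatic carbon gives an at least 1.5-fold lower number from compound 1 to compound 3 (0.18 log units; that floor lies within the scatter). Compound 1 stands only as a limit, so the step has a floor and no full size, and that floor does not rise beyond the scatter: the limit of > 10 ug/mL in this assay, at which 1 of the 3 values shown sits. With hydrogen at this place, compound 3 gives a measured number, 6.54 ug/mL, so the plain phenyl can be read in this assay as a number.

Left open are the true value of compound 1 and how an amine or a methoxy group at this place would read.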